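Removing One Methoxy from Compound 1

The source may hold more compounds than are shown below. What is called first, only, known or untested is meant among the compounds shown, and "the series" means these compounds.

Measured compounds:
compound 1 `COc1ccc(CNc2nc3cc(N)cc(N)c3nc2-c2ccccc2)cc1OC` — 6030 nM
compound 2 `COc1cc(CNc2nc3cc(N)cc(N)c3nc2-c2ccccc2)cc(OC)c1OC` — 1780 nM

In a functional assay on K562 cells (Homo sapiens) for inhibition, read by sulforhodamine B assay, with a stated time of 48 h (on this read-out higher numbers stand for weaker inhibition of growth and lower numbers for stronger inhibition of growth), compound 1 gives 6030 nM, the higher of the two measured numbers; compound 2 gives 1780 nM. Going by the values given here, the single measured step is a 3.4-fold lower number from compound 1 to compound 2 (0.53 log units; beyond the scatter), a methoxy added to the same ring that already carries the two methoxy groups of compound 1. Compound 3 `COc1ccc(CNc2nc3cc(N)cc(N)c3nc2-c2ccccc2)cc1` differs from compound 1 by hydrogen in place of methoxy on an aromatic carbon. Among the compounds with values here, this change runs in the opposite sense to the one measured step: where that step added a methoxy and lowered the number, this step takes one away. On that single comparison, a modest rise in the number is the expectation, estimated as a 2.0-fold higher number from compound 1 to compound 3 (0.30 log units; within the scatter). Compound 3 is therefore expected to give about 12000 nM in this assay, with a range from 5000 nM to 30000 nM.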

Compound 3, concentration for 50% growth inhibition: 25100 nM
The estimate for compound 3 lay 2.1-fold (0.32 log units) below the measured number; low and high end bracket the measured number.
By their numbers in this assay, from the lowest: compound 2; then compound 1; then compound 3.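

In this assay, the change from 3,4-dimethoxyphenyl to 4-methoxyphenyl gives a 4.2-fold higher number from compound 1 to compound 3 (0.62 log units; beyond the scatter), so removing the methoxy from this aromatic carbon, ortho to a methoxy group, is enough on its own to weaken growth inhibition beyond the scatter. The ring has now been changed in both senses, and across compound 3, compound 1 and compound 2 the number falls as methoxy groups are added, with none of the three going against this. Nothing available explains why this position responds in this way.

The compounds shown leave open whether the methoxy itself matters here or whether a hydroxyl group, a chlorine atom or an ethoxy group on this carbon would serve as well. They also leave open what removing the other methoxy of compound 1 would do.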